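Phenyl for ethynyl on the shared nucleoside core

This account rests on a few compounds, and the source may have more. Where it says the series, first, only, none or still open, it means among the compounds named here.

Measured so far:
compound 1 `C#Cc1cn([C@@H]2O[C@H](CO)[C@@H](O)[C@H]2O)c2ncnc(OC)c12` — 5140 nM
compound 2 `Cc1ncnc2c1c(-c1cccs1)cn2[C@@H]1O[C@H](CO)[C@@H](O)[C@H]1O` — > 20000 nM
compound 3 `Nc1nc(N)c2c(-c3ccoc3)cn([C@@H]3O[C@H](CO)[C@@H](O)[C@H]3O)c2n1` — > 20000 nM

Three compounds have been run in a functional assay on HCT-116 cells (Homo sapiens), read by MTT assay, with a stated time of 72 h; a lower number here means a stronger inhibitor, a higher number a weaker inhibitor. Among the compounds with values here, compound 1 is the only one that returns a number, giving 5140 nM. Compound 2 gives only a limit, > 20000 nM. Compound 3 likewise gives only a limit, > 20000 nM. Within the data shown here, the other two results are thus (the limit of > 20000 nM in this assay, at which 2 of the 3 values shown sit), so compound 1 stands alone as the single measured value, and no pair of measured compounds differs in only one place; no step size can be read from the series itself, and compounds 2 and 3 differ from compound 1 in the core as well as in the group on the five-membered ring.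

Compound 4 `COc1ncnc2c1c(-c1ccccc1)cn2[C@@H]1O[C@H](CO)[C@@H](O)[C@H]1O` is the next candidate. Relative to compound 1 it carries phenyl in place of ethynyl on an aromatic carbon.

With nothing to size the change against, the expectation rests on compound 1 alone. The step is expected to be small to moderate and toward weaker inhibition, a 1.6-fold higher number from compound 1 to compound 4 (0.19 log units; within the scatter), with a fair chance that this assay returns only a limit. Compound 4 is estimated at 8000 nM, within a range from 2000 nM to 20000 nM.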

Compound 4, half-maximal inhibitory concentration: > 20000 nM
Compound 4: only a limit was reported (the forecaster's own chance of this, stated with the estimate: 35%); at least 2.5-fold (0.39 log units) between middle value and limit.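

Within the data shown here, compound 1 and compound 4 form the first pair that differs in one place, and in this assay phenyl in place of ethynyl on this aromatic carbon gives an at least 3.8-fold higher number from compound 1 to compound 4 (0.59 log units; beyond the scatter). Compound 4 gives only a limit, > 20000 nM. On the core of compound 1, this position therefore responds to the choice of group, with ethynyl returning a number and phenyl not, but the step is only a lower bound and its full size cannot be read: the limit of > 20000 nM in this assay, at which 3 of the 4 values shown sit.

Still open, going by these compounds, is whether a nitrile, an amine or a longer alkyne chain on this carbon would keep a measurable number in this assay, and so whether ethynyl itself matters or phenyl alone is poorly accepted. Steps from compound 1 to compound 2 or compound 3 cannot be read, as each differs from compound 1 in more than one place, so the thienyl and furyl groups say nothing clean about this position.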